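Moving the methyl on the phenyl ring

The compounds below may be only part of what the source reports. "The series", "measured", "known", "first", "only" and "open" are said of these compounds alone.

The two measured compounds share one core and differ only in the aryl group on the ring nitrogen. Compound 1 `CCCc1nc(-c2ccccc2)c(CNCCCN2CCN(c3cccc(Cl)c3)CC2)o1` gives 65.9% in an assay on HEK293 cells for inhibition of Voltage-dependent T-type calcium channel subunit alpha-1G (Homo sapiens), read by fluorescence, tested at 10 uM; a higher number here means more inhibition at the concentration tested (going by the name of the read-out), a lower number less inhibition. Compound 2 `CCCc1nc(-c2ccccc2)c(CNCCCN2CCN(c3ccc(C)cc3)CC2)o1` gives 53.9% in this assay, the lower of the two numbers shown, and the gap a number 12 percentage points lower from compound 1 to compound 2 (beyond the scatter) is modest but beyond the scatter. The unmeasured compound 3 `CCCc1nc(-c2ccccc2)c(CNCCCN2CCN(c3cccc(C)c3)CC2)o1` differs from compound 2 in one place: 3-methylphenyl in place of 4-methylphenyl on an amine nitrogen in a ring. Among the measured compounds shown here, only one measured step exists, and it bears on this change only indirectly, since compound 1 carries a 3-chlorophenyl, which shares the numeral of its name with the entering 3-methylphenyl, though chloro and methyl differ. That step a number 12 percentage points lower from compound 1 to compound 2 (beyond the scatter) was modest. Nothing measured separates the placement of the methyl from its identity, so the direction is uncertain; a small rise toward the value of compound 1 seems slightly more likely than a fall. Compound 3 is therefore expected to give about 60%, between 45% and 75%, which would be an estimated step of a number 6.1 percentage points higher from compound 2 to compound 3 (within the scatter).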

Compound 3, a percentage reported as inhibition, at one concentration (the size of the read-out at that concentration, not a potency): 47.8%
Compound 3: the middle estimate sits 12.2 percentage points above what was measured; low and high end bracket the measured number.
By their numbers in this assay, from the lowest: compounds 3 and 2 (each within the scatter of the next); then compound 1.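

Among the compounds shown here, with the chloro and the methyl now compared on the same 3-substituted phenyl, the identity of the group can be separated from its placement, which the single earlier step could not do, as it changed both at once. In this assay, methyl in place of chloro on an aromatic carbon gives a number 18.1 percentage points lower from compound 1 to compound 3 (beyond the scatter) and lies beyond the scatter, whereas moving the methyl gives a number 6.1 percentage points lower from compound 2 to compound 3 (within the scatter) and stays within it, so this assay does not tell 3-methylphenyl and 4-methylphenyl apart on the shared core. Among these three compounds, then, the change of chloro to methyl registers and the change of methyl placement does not, and nothing available explains either result.

The compounds shown leave open how a plain phenyl, a fluoro group or a methoxy group on this ring would read in this assay when set against the chloro and methyl compounds. They also leave open whether a chloro group keeps its edge over methyl when the propyl group or the three-carbon chain of the shared core is replaced by a longer chain.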